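The compounds below may be only part of what the source reports. "The series", "measured", "known", "first", "only" and "open" are said of these compounds alone.

In a functional assay on Bel-7402 cells (Homo sapiens) for inhibition, read by MTT assay, with a stated time of 24 h, tested at 100 ug/mL (on this read-out higher numbers stand for more inhibition of growth at the one concentration tested and lower numbers for less inhibition of growth), compound 1 (`CC(=O)SCCC(CCCCC(=O)O)SC(C)=O`) gives 8.35% and so sits well short of the best number seen so far. Compound 3 (`O=C(CCCCC(S)CCS)Nc1ccc(F)cc1`) gives 11.7%, which lies within the usual scatter of compound 1, so these two cannot be told apart. Compound 2 (`O=C(CCCCC1CCSS1)Nc1ccc(Cl)cn1`) gives 48.5% and stands clearly apart from compound 1, beyond the scatter.

The next compound to be tested, compound 4 (`CC(=O)SCCC(CCCCC(=O)Nc1cccc(Cl)c1)SC(C)=O`), keeps the core of compound 1 and changes one end of it: (3-chlorophenyl)amino in place of hydroxy on a carbonyl carbon.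

Going by the values given here, no two measured compounds differ in one place only, so no direct step can guide the expectation. Compound 3 and compound 2 both have an aromatic ring joined through nitrogen to a carbonyl carbon, but each also differs from compound 1 elsewhere. Their values point in different directions, with compound 3 at 11.7% and compound 2 at 48.5% on the same scale. A moderate rise in this assay is therefore expected, held with little confidence. The estimated step is a number 15.7 percentage points higher from compound 1 to compound 4 (beyond the scatter) and could still prove to lie within the scatter. For compound 4 the estimated value is 24%, with an expected range from 8% to 50%.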

Compound 4, percent growth inhibition at one concentration: 20.8%
Estimate against measurement, compound 4: 3.2 percentage points above; measured number inside the range.
By their numbers in this assay, from the lowest: compounds 1, 3 and 4 (each within the scatter of the next, the first and the last beyond it); then compound 2.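

In this assay, putting (3-chlorophenyl)amino in place of hydroxy on a carbonyl carbon, with the rest of the core left as it was, gives a number 12.5 percentage points higher from compound 1 to compound 4 (beyond the scatter). Going by these compounds alone, this is the first comparison in the set in which only one place differs, so it shows that this end of the chain can move the read-out. The move is modest, and it lies beyond the usual scatter of repeated measurements. No measurement shown here explains why the number rises.

The compounds shown leave open whether the rise belongs to the ring, the chlorine or the amide nitrogen itself; phenylamino without the chlorine, or methylamino with no ring at all, would help separate these three parts. Within the data shown here, it also remains open whether the same exchange would give a similar step on a version of the core with free thiol groups in place of the two thioacetyl groups, since the only step available so far comes from a single pair of compounds.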